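Propyl to butyl on the amide chain

This account rests on a few compounds, and the source may have more. Where it says the series, first, only, none or still open, it means among the compounds named here.

In a functional assay on HeLa cells (Homo sapiens) for antiproliferative activity, read by CCK-8 assay, with a stated time of 72 h (a higher number here means a weaker inhibitor of growth, a lower number a stronger inhibitor of growth), compound 1 `CCC1C(=O)N(C)c2cnc(-n3ccc4cc(C(=O)NC)ccc43)nc2N1c1ccn(C)n1` gives 6330 nM and compound 3 `CCCNC(=O)c1ccc2c(ccn2-c2ncc3c(n2)N(c2ccn(C)n2)C(CC)C(=O)N3C)c1` gives 6160 nM. Compound 2 `CCC1C(=O)N(C)c2cnc(-n3ccc4cc(F)ccc43)nc2N1c1ccn(C)n1` is reported as "not active" (no number reported). Compound 3 therefore stands level with compound 1 within the scatter, and no other number is available for comparison. Compound 4 `CCCCNC(=O)c1ccc2c(ccn2-c2ncc3c(n2)N(c2ccn(C)n2)C(CC)C(=O)N3C)c1` differs from compound 3 by methyl in place of hydrogen on a saturated chain carbon, three bonds along the chain from an amide-type nitrogen, which takes propyl to butyl. Among the measured compounds shown here, one measured step bears on this change: ethyl in place of hydrogen on the same chain, a 1.0-fold lower number from compound 1 to compound 3 (0.01 log units; within the scatter), lies within the scatter. On that single step, no change beyond the scatter is expected in this assay. The expected step is a 1.0-fold higher number from compound 3 to compound 4 (0.00 log units; within the scatter). Compound 4 is estimated at 6200 nM, with an expected range of 3000 nM to 12500 nM.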

Compound 4, concentration for 50% growth inhibition: 4260 nM
For compound 4 the middle estimate is 1.5-fold (0.16 log units) above the measured one, within the range that was stated.
By their numbers in this assay, from the lowest: compounds 4, 3 and 1 (each within the scatter of the next).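

In this assay, the butyl chain of compound 4 reads level with the propyl chain of compound 3 (a 1.4-fold lower number from compound 3 to compound 4 (0.16 log units; within the scatter)). Measured against the methyl amide, the chain carbon carrying propyl in place of hydrogen also shows no step beyond the scatter (a 1.5-fold lower number from compound 1 to compound 4 (0.17 log units; within the scatter)). Up to butyl, then, this position has not separated the amides on chain length, and no supporting data explain this reading. On these data alone, whether a longer chain such as hexyl, or a chain ending in an amine or a carboxylic acid, would move the number beyond the scatter remains open.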